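The compounds below may be only part of what the source reports. "The series", "measured", "known", "first", "only" and "open" are said of these compounds alone.

In a functional assay on 786-0 cells (Homo sapiens) for inhibition, read by sulforhodamine B assay, with a stated time of 48 h (a lower number here means a stronger inhibitor of growth, a higher number a weaker inhibitor of growth), compound 3 `Nc1cc(N)c2nc(-c3ccccc3)c(NCc3ccc(F)cc3)nc2c1` gives 23400 nM, a number within the scatter of both compound 1 `Nc1cc(N)c2nc(-c3ccccc3)c(NCc3ccc(Cl)c(Cl)c3)nc2c1` with 13200 nM and compound 2 `COc1ccc(CNc2nc3cc(N)cc(N)c3nc2-c2ccccc2)cc1OC` with 15500 nM. The step to compound 4 `COc1ccc(CNc2nc3cc(N)cc(N)c3nc2-c2ccccc2)cc1` is methoxy in place of fluoro on an aromatic carbon. The nearest measured step is the one that read a 1.5-fold higher number from compound 2 to compound 3 (0.18 log units; within the scatter), which swaps a dimethoxyphenyl for the fluorophenyl, and the step of a 1.8-fold higher number from compound 1 to compound 3 (0.25 log units; within the scatter) was also within the scatter. Since neither change of this benzyl group moved this assay beyond the scatter, the expected step of a 1.4-fold lower number from compound 3 to compound 4 (0.14 log units; within the scatter) is small and without clear direction. Compound 4 is therefore estimated at 17000 nM, with a range from 8000 nM to 36000 nM.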

Compound 4, concentration for 50% growth inhibition: 15100 nM
Beside the measured number, compound 4's estimate is 1.1-fold (0.05 log units) above it, and the stated range covers the measured number.
By their numbers in this assay, from the lowest: compounds 1, 4, 2 and 3 (each within the scatter of the next).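

In this assay, methoxy in place of fluoro on an aromatic carbon, para to a large group, stays within the scatter (a 1.5-fold lower number from compound 3 to compound 4 (0.19 log units; within the scatter)). Hydrogen in place of one methoxy of the 3,4-dimethoxyphenyl also stays within it (a 1.0-fold lower number from compound 2 to compound 4 (0.01 log units; within the scatter)), as does 4-methoxyphenyl in place of 3,4-dichlorophenyl (a 1.1-fold higher number from compound 1 to compound 4 (0.06 log units; within the scatter)), so these four benzyl groups cannot be told apart here. No supporting measurement bears on this result. From the compounds shown here alone, whether an amine or a carboxylic acid at this place, or a longer chain in place of the benzyl group, would move the number beyond the scatter remains open.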